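The source may hold more compounds than are shown below. What is called first, only, known or untested is meant among the compounds shown, and "the series" means these compounds.

Compound 1 `C=C1C(=O)O[C@H]2[C@H]1CC/C(COC(=O)Cn1cc(F)c(=O)[nH]c1=O)=C\CC[C@@]1(C)O[C@@H]21` was tested in a functional assay on Bel-7402 cells (Homo sapiens) for antiproliferative activity, read by MTT assay, with a stated time of 72 h; a higher number here means a weaker inhibitor, a lower number a stronger inhibitor. In this assay compound 1 gives > 20000 nM, which is a limit of the assay rather than a measured number. Compound 2 `C=C1C(=O)O[C@H]2[C@H]1CC/C(COC(=O)CCC(=O)N1CCN(C(=O)Cn3cc(F)c(=O)[nH]c3=O)CC1)=C\CC[C@@]1(C)O[C@@H]21` was examined in the same way; in this assay compound 2 gives > 20000 nM, again a limit and not a number. Every value shown thus sits at the limit of > 20000 nM in this assay, at which 2 of the 2 values shown sit, so compound 1 stands at the same point as all the rest, with no number of its own. Compound 3 `C=C1C(=O)O[C@H]2[C@H]1CC/C(COC(=O)Cn1cc(F)c(=O)n(Cc3ccc(F)c(F)c3)c1=O)=C\CC[C@@]1(C)O[C@@H]21` has not yet been measured. It differs from compound 1 in one place: 3,4-difluorobenzyl in place of hydrogen on an aromatic nitrogen. Among the compounds with values here, no step between two measured compounds is available here, so nothing measured guides this change. The step of an at least 1.3-fold lower number from compound 1 to compound 3 (0.12 log units; that floor lies within the scatter) is expected to be small, if anything toward a lower number, and to stay within the usual scatter. Compound 3 is therefore estimated at about 15000 nM, between 5000 nM and 40000 nM.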

Compound 3, half-maximal inhibitory concentration: 2700 nM
The estimate for compound 3 lay 5.6-fold (0.74 log units) above the measured number; the whole stated range lies above it.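

Placing 3,4-difluorobenzyl on the aromatic nitrogen of compound 1 produces a change that can be seen: in this assay the swap of hydrogen for this group gives an at least 7.4-fold lower number from compound 1 to compound 3 (0.86 log units; beyond the scatter) and so moves beyond the scatter. Compound 3 is the only compound here with a measured number, which makes this nitrogen the first place shown where a change lifts a compound off the limit. Going by these compounds, the true size of the step remains unknown because compound 1 has a limit and no number of its own: the limit of > 20000 nM in this assay, at which 2 of the 3 values shown sit.

Plain benzyl, methyl or a longer alkyl chain on the same nitrogen would show whether the benzyl ring or its two fluoro groups carry the effect. On these data alone, whether 3,4-difluorobenzyl on the same nitrogen of compound 2 would act in the same way also stays open.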